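Solubility of Compound 3 Expected at the Assay Limit

This account rests on a few compounds, and the source may have more. Where it says the series, first, only, none or still open, it means among the compounds named here.

Compound 1, `COC(=O)[C@H](C)N(C)C(=O)c1c(C)cc(-c2cccc(NS(=O)(=O)c3cc(C)c(Cl)cc3C)c2)cc1C`, gives < 4000 nM in a physicochemical assay for solubility, at pH 6.8 (on this read-out lower numbers stand for lower solubility and higher numbers for higher solubility), which is a limit of the assay rather than a number.
Compound 2, `COC(=O)[C@H](CN(C)C)N(C)C(=O)c1c(C)cc(-c2cccc(NS(=O)(=O)c3cc(C)c(Cl)cc3C)c2)cc1C`, gives < 4000 nM in this assay, again a limit.

Among the measured compounds shown here, compound 2 therefore stands at the lower end of what this assay can report, and the only measured step, a step that the two limits leave unreadable from compound 1 to compound 2, cannot be read because of the limit of < 4000 nM in this assay, at which 2 of the 2 values shown sit. Compound 3, `CCOC(=O)[C@H](CCN(C)C)NC(=O)c1c(C)cc(-c2cccc(NS(=O)(=O)c3cc(C)c(Cl)cc3C)c2)cc1C`, differs from compound 2 by a group of 12 heavy atoms (8 carbon, 2 nitrogen, 2 oxygen; no ring) in place of a group of 11 heavy atoms (7 carbon, 2 nitrogen, 2 oxygen; no ring), on a carbonyl carbon. For the measured compounds named here, the one measured step bears on this change only in that both of its ends sit at the limit, so it gives no size or direction for the new step. Compound 3 is expected to show a step that the limit leaves unreadable from compound 2 to compound 3, nothing beyond the scatter. The estimate for compound 3 is 2500 nM, with a range from 600 nM to 8000 nM, most likely reported again as a limit.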

Compound 3, solubility: < 4000 nM
Compound 3 gave a limit, no number; the forecaster's own chance of this, stated with the estimate: 70%; the middle value does not contradict the limit.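

Among the compounds shown here, compound 3 again gives a limit and not a number, so no step among compound 1, compound 2 and compound 3 can be read, because all three sit at the same limit: the limit of < 4000 nM in this assay, at which 3 of the 3 values shown sit. As far as these compounds go, what stays open is how the true values of these three compounds compare in this assay and whether any of the changes between them makes a real difference.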